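This account rests on a few compounds, and the source may have more. Where it says the series, first, only, none or still open, it means among the compounds named here.

Measured in a functional assay on a cell-free system (plasma, Oryctolagus cuniculus) for inhibition, with stated times of 5 min, 1 min and 6 min; on this read-out lower numbers stand for stronger inhibition and higher numbers for weaker inhibition:
- compound 1 `CCOC(=O)c1c(C)nc(-c2cccc(C#N)c2)n1OCCCO`: 11400 nM
- compound 2 `CCOC(=O)c1c(C)nc(-c2cccc(C#N)c2)n1OCc1ccc(Br)cc1`: 24600 nM
- compound 3 `CCOC(=O)c1c(C)nc(-c2cccc(C#N)c2)n1OCc1ccc([N+](=O)[O-])cc1`: 8750 nM

Compound 3 stands level with compound 1, as a 1.3-fold lower number from compound 1 to compound 3 (0.11 log units; within the scatter) shows, and clearly under compound 2, as a 2.8-fold lower number from compound 2 to compound 3 (0.45 log units; beyond the scatter) shows. Compound 4 `CCOC(=O)c1c(C)nc(-c2cccc(C#N)c2)n1OCc1ccc(C#N)cc1` has cyano in place of nitro on an aromatic carbon, para to a large group (cyano in place of nitro on an aromatic carbon). Among the measured compounds shown here, the step from bromo to nitro is the only measured change at that place, and it was modest. The steps of a 2.2-fold higher number from compound 1 to compound 2 (0.33 log units; beyond the scatter) and a 1.3-fold lower number from compound 1 to compound 3 (0.11 log units; within the scatter) replace a larger piece and bear on it less. No cyano at that place has been measured, so a step beyond the scatter is not expected. The expected step is a 1.1-fold higher number from compound 3 to compound 4 (0.06 log units; within the scatter). For compound 4 the estimated value is 10000 nM, with an expected range from 5000 nM to 20000 nM.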

Compound 4, half-maximal inhibitory concentration: 4240 nM
Beside the measured number, compound 4's estimate is 2.4-fold (0.37 log units) above it; measured number below the stated range.
By their numbers in this assay, from the lowest: compound 4; then compounds 3 and 1 (each within the scatter of the next); then compound 2.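

Cyano at this aromatic carbon gives a 2.1-fold lower number from compound 3 to compound 4 (0.31 log units; beyond the scatter) and, set against bromo, a 5.8-fold lower number from compound 2 to compound 4 (0.76 log units; beyond the scatter) so three groups at this one place now separate beyond the scatter, with cyano giving the lowest number. The step of a 2.7-fold lower number from compound 1 to compound 4 (0.43 log units; beyond the scatter) also puts this compound clear of the one carrying the hydroxyl chain, which the nitro compound did not manage. No measurement at hand explains why cyano gives the lower number. On these data alone, whether an amine or a carboxylic acid at this place would fall lower still remains open.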